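Variations at the nitrogen substituent on the shared core

A few compounds are considered here, and "the series" means these few. Any claim that something is new, unique, unknown or untested is made for them only; others in the source may bear on it.

Compound 3 `CC(C(=O)NCc1ccc(C(F)(F)F)nc1NCc1cccnc1)c1ccc(NS(C)(=O)=O)c(F)c1` is reported as "not active" (no number reported) in a functional assay on CHO-K1 cells for antagonist activity at transient receptor potential cation channel subfamily V member 1 (Homo sapiens), read by FLIPR; on this read-out lower numbers stand for stronger inhibition and higher numbers for weaker inhibition; no number stands for it, so it cannot be placed among the measured values. Compound 1 `CCCCNc1nc(C(F)(F)F)ccc1CNC(=O)C(C)c1ccc(NS(C)(=O)=O)c(F)c1` gives 9.1 nM in this assay, and compound 2 `CC1CCC(Nc2nc(C(F)(F)F)ccc2CNC(=O)C(C)c2ccc(NS(C)(=O)=O)c(F)c2)CC1` gives 27.2 nM; the step of a 3.0-fold higher number from compound 1 to compound 2 (0.48 log units; beyond the scatter) is the only one available and concerns a change at a nitrogen on an aromatic ring. Compound 4 `CCCN(CCC)c1nc(C(F)(F)F)ccc1CNC(=O)C(C)c1ccc(NS(C)(=O)=O)c(F)c1` differs from compound 3 by dipropylamino in place of ((pyridin-3-yl)methyl)amino on an aromatic carbon. Within the data shown here, no measured step covers this exchange, and the starting point of compound 3 has no number; compound 1, carrying butyl at that nitrogen, gives 9.1 nM, which guides the expectation. Compound 4 is therefore expected to fall near 80 nM, within 10 nM to 800 nM, in this assay.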

Compound 4, inhibition constant: 0.2 nM
For compound 4 the middle estimate is 400-fold (2.60 log units) above the measured one, and the stated range ends above it.
By their numbers in this assay, from the lowest: compound 4; then compound 1; then compound 2.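

Among these compounds, at this aromatic carbon, dipropylamino gives a 46-fold lower number from compound 1 to compound 4 (1.66 log units; beyond the scatter) in this assay and a 140-fold lower number from compound 2 to compound 4 (2.13 log units; beyond the scatter) in the same read-out, both steps being far larger than a 3.0-fold higher number from compound 1 to compound 2 (0.48 log units; beyond the scatter) among the earlier compounds. The position is therefore much more sensitive to the amino group than the butylamino and (4-methylcyclohexyl)amino pair suggested, and of the compounds with numbers, compound 4 alone carries two chains on this nitrogen. No measurement shown explains these steps. As far as these compounds go, a single compound cannot show whether having two chains or their propyl length matters; dimethylamino, dibutylamino and piperidine at this carbon remain open.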